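The compounds below may be only part of what the source reports. "The series", "measured", "known", "first", "only" and "open" are said of these compounds alone.

Measured in an assay on cells for displacement of a labelled ligand from adenosine receptor A1 (Homo sapiens), read by radioligand binding, with a stated time of 60 min, tested at 1 uM; on this read-out higher numbers stand for more inhibition at the one concentration tested (going by the name of the read-out) and lower numbers for less inhibition:

compound 1, `CC(C)OC(=O)C1=C(C(F)(F)F)NC(=O)NC1c1ccsc1`: 23%
compound 2, `CC(C)OC(=O)C1=C(C(F)(F)F)NC(=O)NC1c1ccoc1`: 27%
compound 3, `CCOC(=O)C1=C(C(F)(F)F)NC(=O)NC1c1ccsc1`: 32%

All three compounds share one core and differ only in the ester group and in the five-membered aromatic ring attached to a saturated ring carbon. Compound 3 stands at the top of the three numbers as written, but its gap to compound 2 and its gap to compound 1 both lie within the scatter of this assay, so the three are, in effect, indistinguishable.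

Compound 4, `CCOC(=O)C1=C(C(F)(F)F)NC(=O)NC1c1ccoc1`, is obtained from compound 3 by a single exchange: furan-3-yl in place of thiophen-3-yl on a saturated ring carbon. The same exchange has been measured once already, on the isopropyl ester pair: a number 4 percentage points higher from compound 1 to compound 2 (within the scatter). The other step seen so far, a number 9 percentage points higher from compound 1 to compound 3 (within the scatter), concerns the ester and not the aromatic ring, so it does not bear on this question. Going by the values given here, with only one precedent, and that one within the scatter, the expectation for this assay is a step of a number 3 percentage points higher from compound 3 to compound 4 (within the scatter), that is, no change beyond the scatter. Compound 4 is therefore expected to give about 35%, with a likely range from 22% to 48%.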

Compound 4, a percentage reported as inhibition, at one concentration (the size of the read-out at that concentration, not a potency): 37%
Estimate against measurement, compound 4: 2 percentage points below; the measured number falls inside the stated range.
By their numbers in this assay, from the lowest: compounds 1, 2, 3 and 4 (each within the scatter of the next, the first and the last beyond it).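

On the ethoxycarbonyl compounds in this assay, furan-3-yl in place of thiophen-3-yl gives a number 5 percentage points higher from compound 3 to compound 4 (within the scatter), so this exchange on the saturated ring carbon now has a second reading, and the two readings agree: the same change on two cores in this assay, a number 4 percentage points higher (within the scatter) from compound 1 to compound 2 and a number 5 percentage points higher (within the scatter) from compound 3 to compound 4, 1 percentage points apart, within the scatter of two such steps

The ester change can now also be read with furan-3-yl on the ring, where it gives a number 10 percentage points higher from compound 2 to compound 4 (within the scatter), and it repeats what was seen with thiophen-3-yl: the same change on two cores in this assay, a number 9 percentage points higher (within the scatter) from compound 1 to compound 3 and a number 10 percentage points higher (within the scatter) from compound 2 to compound 4, 1 percentage points apart, within the scatter of two such steps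

Across these four compounds, the size of each change therefore does not appear to depend on the other, although no single step leaves the scatter.

The compounds shown leave open whether a six-membered aromatic ring such as phenyl or pyridyl on the saturated ring carbon would move the number beyond the scatter. They also leave open what a carboxylic acid, an amide or a longer chain such as a butyl ester would do in place of the present esters, and whether the two changes would still keep their sizes there.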